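Swapping the aryl group on a shared core

A few compounds are considered here, and "the series" means these few. Any claim that something is new, unique, unknown or untested is made for them only; others in the source may bear on it.

Compound 1 (`COc1ccc(C2CC(=O)c3ccc(OCC=C(C)C)cc3O2)cc1`) : 10200 nM
Compound 2 (`CC(C)=CCOc1ccc2c(c1)OC(c1ccc(C)cc1C)CC2=O`) : 8260 nM

Both numbers come from a functional assay; a higher number here means a weaker inhibitor, a lower number a stronger inhibitor. Within the data shown here, with only these two values available, compound 2 cannot be separated from compound 1, as the one measured step shows: a 1.2-fold lower number from compound 1 to compound 2 (0.09 log units; within the scatter).

Compound 3 (`CC(C)=CCOc1ccc2c(c1)OC(c1ccc(O)cc1)CC2=O`) keeps the shared core of compound 2 and carries 4-hydroxyphenyl in place of 2,4-dimethylphenyl on a saturated ring carbon. Among the measured compounds shown here, the same carbon changed between compound 1 and compound 2, so that step is the only guide. For the measured compounds named here, the single swap measured there (a 1.2-fold lower number from compound 1 to compound 2 (0.09 log units; within the scatter)) gives no reason to expect a step beyond the scatter in this assay. Going by the values given here, one step is thin evidence, however, and no measured compound carries a 4-hydroxyphenyl group, so the expected range must stay wide.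

The expected change is a 1.3-fold lower number from compound 2 to compound 3 (0.10 log units; within the scatter). For compound 3 the estimated value is 6500 nM, with an expected range from 2200 nM to 19000 nM.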

Compound 3, half-maximal inhibitory concentration: 6670 nM
The estimate for compound 3 lay 1.0-fold (0.01 log units) below the measured number; measured number inside the range.
By their numbers in this assay, from the lowest: compounds 3, 2 and 1 (each within the scatter of the next).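

In this assay, this carbon next to the ring oxygen takes a 4-hydroxyphenyl group in place of 2,4-dimethylphenyl, bringing in a hydrogen-bond donor and a hydrogen-bond acceptor that the departing group lacks, yet the two compounds still cannot be told apart (a 1.2-fold lower number from compound 2 to compound 3 (0.09 log units; within the scatter)). Exchanging the methyl on the oxygen of compound 1 for hydrogen, the smallest edit among these compounds, gives the same kind of answer (a 1.5-fold lower number from compound 1 to compound 3 (0.18 log units; within the scatter)), so the three aryl groups shown cannot be ranked, and a free hydroxyl on the aryl ring makes no readable difference here. Nothing measured alongside these numbers speaks to why the three compounds read alike.

The compounds shown do not reveal whether any change at this carbon can move the number beyond the scatter, since all three aryl groups give values that sit close together. An aryl ring carrying an amine or a carboxylic acid, or a longer chain in place of the aryl ring, would test this carbon far more severely.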